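Replacing One Side Chain: Will the Half-Life Hold?

The compounds below may be only part of what the source reports. "The series", "measured", "known", "first", "only" and "open" are said of these compounds alone.

In an ADME assay on Caecum (Rattus norvegicus, strain Sprague-Dawley) for metabolic stability, read by LC-MS, tested at 10 uM (a higher number here means that the compound lasts longer, a lower number that the compound disappears faster), two compounds have been measured so far. Compound 1 `C[C@@H](N[C@H]1CCN(c2ccc(S(=O)(=O)NC(=O)CCC(=O)O)cc2)C1)c1cccc2ccccc12` gives 10.5 h, and compound 2 `C[C@@H](N[C@H]1CCN(c2ccc(C(=O)N(C)[C@@H](O)[C@H](O)[C@H](O)[C@@H](O)CO)cc2)C1)c1cccc2ccccc12` gives 11 h. These two values lie within the usual scatter of repeated measurements, so compound 2 stands level with compound 1 and the numbers cannot separate them.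

Compound 3 `C[C@@H](N[C@H]1CCN(c2ccc(C(=O)N[C@H](CC(=O)O)C(=O)O)cc2)C1)c1cccc2ccccc12` keeps the shared core of compound 2 but changes the group on a carbonyl carbon: (1,2-dicarboxyethyl)amino in place of methyl(1,2,3,4,5-pentahydroxypentyl)amino ((1,2-dicarboxyethyl)amino in place of methyl(1,2,3,4,5-pentahydroxypentyl)amino on a carbonyl carbon). Going by the values given here, no two measured compounds differ in only one place, so the data do not show directly what a single change of this kind does.

Among the compounds with values here, the only guide is indirect: compound 1 carries a different side chain on the shared core and still gives 10.5 h. On that basis, no change beyond the scatter is expected in this assay, and no direction is favoured. The estimated step of a 1.1-fold lower number from compound 2 to compound 3 (0.04 log units; within the scatter) is therefore small. For compound 3, the expected half-life is 10 h, with an estimated range of 5 h to 20 h.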

Compound 3, half-life: 9.1 h
Estimate against measurement, compound 3: 1.1-fold (0.04 log units) above, within the range that was stated.
By their numbers in this assay, from the lowest: compounds 3, 1 and 2 (each within the scatter of the next).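

On the carbonyl carbon of the shared core, the two side chains are interchangeable as far as this assay can tell: putting (1,2-dicarboxyethyl)amino in place of methyl(1,2,3,4,5-pentahydroxypentyl)amino gives a 1.2-fold lower number from compound 2 to compound 3 (0.08 log units; within the scatter). This holds even though the group that enters has fewer heavy atoms, fewer defined stereocentres and fewer hydrogen-bond donors than the one it replaces, and the second comparison points the same way, with (1,2-dicarboxyethyl)carbamoyl in place of ((2-carboxyethyl)carbonyl)sulfamoyl on an aromatic carbon giving a 1.2-fold lower number from compound 1 to compound 3 (0.06 log units; within the scatter). So the three side chains, which differ widely in their atoms, cannot be told apart by half-life here, and no other measurement says what lies behind this.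

The compounds shown leave open whether this position would respond to a much simpler group, such as a dimethylamino group or a plain hexyl chain carrying neither hydroxyl nor carboxylic acid groups. They also leave open whether the defined stereocentre in (1,2-dicarboxyethyl)amino matters, which its mirror-image form on the same carbonyl carbon could test.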